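Methylsulfonyl in place of methylsulfanyl in an electroshock series

A few compounds are considered here, and "the series" means these few. Any claim that something is new, unique, unknown or untested is made for them only; others in the source may bear on it.

Three compounds have been measured in a functional assay on the whole organism for antagonist activity, with Mus musculus as the target, in the maximal electroshock model; a lower number here means that less compound is needed, a higher number that more compound is needed for the effect:
compound 1, `CSc1nnc(-c2cccc3ccccc23)n1C`: compound 1 gives > 200 mg/kg, which is a limit of the assay.
compound 2, `Cn1c(-c2cccc3ccccc23)nnc1S(C)(=O)=O`: compound 2 gives > 200 mg/kg, again a limit of the assay.
compound 3, `CSc1nc(-c2ccc(Cl)cc2)nn1C`: compound 3 gives > 200 mg/kg, also a limit of the assay.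

The change from compound 1 to compound 2 is methylsulfonyl in place of methylsulfanyl on an aromatic carbon. Its size is a step that the two limits leave unreadable from compound 1 to compound 2, and it cannot be read because of the limit of > 200 mg/kg in this assay, at which 3 of the 3 values shown sit.

Compound 4, `Cn1nc(-c2ccc(Cl)cc2)nc1S(C)(=O)=O`, stands to compound 3 as compound 2 stands to compound 1; the difference is methylsulfonyl in place of methylsulfanyl on an aromatic carbon. It is the same kind of change, though the surroundings differ: in compound 1 the changed carbon is two ring bonds from the ring atom that bears a large group, in compound 3 from the ring atom that bears a group of 7 heavy atoms. The difference between the two cores is not broken down here.

In this assay the step from compound 3 to compound 4 is expected to be a step that the limit leaves unreadable from compound 3 to compound 4, resting on the fact that (the limit of > 200 mg/kg in this assay, at which 3 of the 3 values shown sit). Compound 4 is therefore estimated at 400 mg/kg, between 150 mg/kg and 2000 mg/kg, and the assay is expected most likely to return only a limit once more.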

Compound 4, dose for half-maximal effect: > 200 mg/kg
Compound 4: only a limit was reported; the forecaster's own chance of this, stated with the estimate: 85%; the middle value lies beyond the limit too.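

The step between compound 3 and compound 4 cannot be read in this assay, because both compounds sit at a limit of the assay: the limit of > 200 mg/kg in this assay, at which 4 of the 4 values shown sit. The compounds shown leave open whether methylsulfonyl in place of methylsulfanyl on an aromatic carbon changes the dose needed at all, and in which direction, as none of them gives a number.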